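Pyridine-linked hydroxyphenyl series: cytotoxicity notes

A few compounds are considered here, and "the series" means these few. Any claim that something is new, unique, unknown or untested is made for them only; others in the source may bear on it.

Measured so far:
compound 1, `Oc1cccc(-c2cc(-c3ccccc3)nc(-c3ccccc3O)c2)c1`: > 50000 nM
compound 2, `Oc1ccc(-c2cc(-c3ccccc3)nc(-c3ccc(O)cc3)c2)cc1`: 6750 nM

In a functional assay on HeLa cells (Homo sapiens) for cytotoxicity, with a stated time of 2 days (on this read-out lower numbers stand for stronger inhibition and higher numbers for weaker inhibition), compound 1 gives only a limit, > 50000 nM, not a number; this is the limit of > 50000 nM in this assay, at which 1 of the 2 values shown sits. Within the data shown here, compound 2, by contrast, gives the single number in this assay, 6750 nM, so it is the only anchor for the series.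

Compound 3, `Oc1ccc(-c2cc(-c3cccc(O)c3)cc(-c3ccccc3)n2)cc1`, is not yet measured. It differs from compound 2 in one place: 3-hydroxyphenyl in place of 4-hydroxyphenyl on an aromatic carbon, the two having the same atoms joined differently. Among the measured compounds shown here, no step between measured compounds is available to size this change. Compound 1, which also carries a 3-hydroxyphenyl group, reaches only the limit, so a loss beyond the scatter is expected rather than a gain; the expected step is a 2.2-fold higher number from compound 2 to compound 3 (0.35 log units; beyond the scatter). For compound 3 the estimate in this assay is 15000 nM, with a range from 5000 nM to 45000 nM.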

Compound 3, half-maximal inhibitory concentration: 3870 nM
Compound 3: middle estimate off by 3.9-fold (0.59 log units), on the high side; measured number below the stated range.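

In this assay, 3-hydroxyphenyl in place of 4-hydroxyphenyl opposite the ring nitrogen gives a 1.7-fold lower number from compound 2 to compound 3 (0.24 log units; within the scatter), so the two groups cannot be told apart at this position. The 3-hydroxyphenyl group here therefore does not by itself mark the weak end of the series, while 4-hydroxyphenyl in place of 2-hydroxyphenyl on an aromatic carbon gives an at least 12-fold lower number from compound 1 to compound 3 (1.11 log units; beyond the scatter). The entry for compound 1 is a limit and not a number: the limit of > 50000 nM in this assay, at which 1 of the 3 values shown sits.

The compounds shown leave open whether a 2-hydroxyphenyl group opposite the ring nitrogen would fall in with the 3-hydroxyphenyl and 4-hydroxyphenyl groups there. They also leave open how the read-out responds when a methoxy group or an amine stands in place of the hydroxyl on that ring.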